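A Third Methoxy Group Added to Compound 3

The source may report more compounds than this note shows. Statements on the series, on what has been measured and on what is new or still open speak of the compounds shown alone.

Compound 1, `COc1ccc2nc(NC(=O)c3cc(-c4ccc(OC)c(OC)c4)n4nc(-c5ccccc5)cc4n3)sc2c1`: 15800 nM
Compound 2, `COc1ccc(-c2cc(C(=O)Nc3nc4ccccc4s3)nc3cc(-c4ccccc4)nn23)cc1OC`: 5490 nM
Compound 3, `COc1ccc(-c2cc(C(=O)Nc3nc4cc(C)c(C)cc4s3)nc3cc(-c4ccccc4)nn23)cc1OC`: 2950 nM

All three numbers come from a functional assay on A549 cells (Homo sapiens) for cytotoxicity, read by MTT assay, with a stated time of 48 h; a lower number here means a stronger inhibitor, a higher number a weaker inhibitor. Compound 2 and compound 3 share a core and differ by 5,6-dimethyl-1,3-benzothiazol-2-yl in place of 1,3-benzothiazol-2-yl on an amide-type nitrogen; the step of a 1.9-fold lower number from compound 2 to compound 3 (0.27 log units; within the scatter), so their two values cannot be told apart. Compound 1 differs from compound 2 by methoxy in place of hydrogen on an aromatic carbon, and the step is a 2.9-fold higher number from compound 2 to compound 1 (0.46 log units; beyond the scatter). From compound 1 to compound 3 the step is a 5.4-fold lower number from compound 1 to compound 3 (0.73 log units; beyond the scatter).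

Compound 4, `COc1cc(-c2cc(C(=O)Nc3nc4cc(C)c(C)cc4s3)nc3cc(-c4ccccc4)nn23)cc(OC)c1OC`, is not yet measured. It differs from compound 3 by methoxy in place of hydrogen on an aromatic carbon. This is the same kind of change as from compound 2 to compound 1, but not the same: there the new group sat on a six-membered aromatic ring of carbon only, part of a fused system of two rings, meta and para to a fused ring; here it sits on a six-membered aromatic ring of carbon only, ortho to a methoxy group, meta to a large group and meta to a methoxy group. The earlier step rests on a single pair, so it is a weak guide. Within the data shown here, compound 4 is expected to give a higher number than compound 3, the step estimated as a 2.0-fold higher number from compound 3 to compound 4 (0.31 log units; beyond the scatter) because the only comparable step, a 2.9-fold higher number from compound 2 to compound 1 (0.46 log units; beyond the scatter), went that way. The estimate for compound 4 in this assay is 6000 nM, with a plausible range from 2000 nM to 18000 nM.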

Compound 4, half-maximal inhibitory concentration: 2340 nM
Compound 4: the middle estimate sits 2.6-fold (0.41 log units) above what was measured, and the stated range covers the measured number.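

In this assay, adding the third methoxy group gives a 1.3-fold lower number from compound 3 to compound 4 (0.10 log units; within the scatter), so compound 3 and compound 4 cannot be told apart. Replacing hydrogen with methoxy therefore did not have the same outcome in the two pairs: the same change on two cores in this assay, a 2.9-fold higher number (0.46 log units; beyond the scatter) from compound 2 to compound 1 and a 1.3-fold lower number (0.10 log units; within the scatter) from compound 3 to compound 4, 3.6-fold (0.56 log units) apart, beyond the scatter of two such steps. This shows that the step seen in the first pair did not carry over to the second, but each result rests on a single pair and the methoxy sits on a different ring in each, so it does not show whether the core or the place of the group accounts for the gap, or what the change would do on a further core.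

The compounds shown leave open what a hydroxyl group, an amine or a carboxylic acid would do in the place taken by the third methoxy group of compound 4. They also leave open how a longer chain, such as ethoxy, would compare there with methoxy in this assay.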